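Aminocrotonamide quinazolines: amine swap on a tetrahydroquinoline core

This account rests on a few compounds, and the source may have more. Where it says the series, first, only, none or still open, it means among the compounds named here.

Compound 1 `CCN(CC)C/C=C/C(=O)Nc1cc2c(N3CCc4ccccc43)ncnc2cc1OC` is the reference. In a functional assay on PC-3 cells (Homo sapiens) for antiproliferative activity, read by MTT assay, with a stated time of 72 h (a lower number here means a stronger inhibitor, a higher number a weaker inhibitor), compound 1 gives 3690 nM. Compound 2 `COc1cc2ncnc(N3CCc4ccccc43)c2cc1NC(=O)/C=C/CN1CCCC1` carries the change (pyrrolidin-1-yl in place of diethylamino on a saturated chain carbon bound to a double-bonded chain carbon); compound 2 gives 2620 nM, a step of a 1.4-fold lower number from compound 1 to compound 2 (0.15 log units; within the scatter). Compound 3 `CCN(CC)C/C=C/C(=O)Nc1cc2c(N3CCCc4ccccc43)ncnc2cc1OC` differs from compound 1 in the core, (1,2,3,4-tetrahydroquinolin-1-yl in place of 2,3-dihydro-1H-indol-1-yl on an aromatic carbon). Compound 3 gives 6890 nM, a step of a 1.9-fold higher number from compound 1 to compound 3 (0.27 log units; within the scatter). Compound 4 `COc1cc2ncnc(N3CCCc4ccccc43)c2cc1NC(=O)/C=C/CN1CCCC1` is not yet measured; it differs from compound 3 by pyrrolidin-1-yl in place of diethylamino on a saturated chain carbon bound to a double-bonded chain carbon, the same change as that from compound 1 to compound 2, made at the same place, but on the core of compound 3. The step is expected to resemble a 1.4-fold lower number from compound 1 to compound 2 (0.15 log units; within the scatter), so the estimated step is a 1.4-fold lower number from compound 3 to compound 4 (0.15 log units; within the scatter). For compound 4 the estimate in this assay is 4900 nM, between 2500 nM and 10000 nM.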

Compound 4, half-maximal inhibitory concentration: 1740 nM
For compound 4 the middle estimate is 2.8-fold (0.45 log units) above the measured one, outside the stated range (below it).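

On the core of compound 3, pyrrolidin-1-yl in place of diethylamino gives a 4.0-fold lower number from compound 3 to compound 4 (0.60 log units; beyond the scatter), so the size of this change does not carry over from the core of compound 1: the same change on two cores in this assay, a 1.4-fold lower number (0.15 log units; within the scatter) from compound 1 to compound 2 and a 4.0-fold lower number (0.60 log units; beyond the scatter) from compound 3 to compound 4, 2.8-fold (0.45 log units) apart, beyond the scatter of two such steps. Read the other way, with pyrrolidin-1-yl on the chain, the core change gives a 1.5-fold lower number from compound 2 to compound 4 (0.18 log units; within the scatter), which does not match the step seen with diethylamino: the same change on two cores in this assay, a 1.9-fold higher number (0.27 log units; within the scatter) from compound 1 to compound 3 and a 1.5-fold lower number (0.18 log units; within the scatter) from compound 2 to compound 4, 2.8-fold (0.45 log units) apart, beyond the scatter of two such steps. The amine and core changes are therefore not additive across these four compounds in this assay, but a single set of four shows neither how general this is nor what causes it.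

As far as these compounds go, whether the larger step on the core of compound 3 recurs with another amine, such as piperidin-1-yl or morpholin-4-yl, remains open. Also open, from the compounds shown here alone, is whether dimethylamino would follow diethylamino or pyrrolidin-1-yl on either core.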